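Swapping bromo for chloro on compound 3

This account rests on a few compounds, and the source may have more. Where it says the series, first, only, none or still open, it means among the compounds named here.

Compound 1 `CC#CCn1c(N2CCC[C@@H](N)C2)nc2c1c(=O)n(Cc1ccc(Br)cc1C(=O)OCC)c(=O)n2C`: 98.4%
Compound 2 `CC#CCn1c(N2CCC[C@@H](N)C2)nc2c1c(=O)n(Cc1ccc(Cl)cc1C(=O)OCc1oc(=O)oc1C)c(=O)n2C`: 12%
Compound 3 `CC#CCn1c(N2CCC[C@@H](N)C2)nc2c1c(=O)n(Cc1ccc(Br)cc1C(=O)O)c(=O)n2C`: 99.2%

These values come from a physicochemical assay for metabolic stability, read by LC-MS, in phosphate buffer, with a stated time of 120 min, at pH 7.4, tested at 1 uM; on this read-out lower numbers stand for a less stable compound and higher numbers for a more stable compound. Compound 3, at 99.2%, sits level with compound 1 within the scatter, while compound 2 reads 12%, far lower.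

Compound 4 `CC#CCn1c(N2CCC[C@@H](N)C2)nc2c1c(=O)n(Cc1ccc(Cl)cc1C(=O)O)c(=O)n2C` has not yet been measured. Its structure differs from that of compound 3 by chloro in place of bromo on an aromatic carbon, meta to a carboxy group and para to a large group.

For the measured compounds named here, no measured step makes this swap. Going by the values given here, the one step available, a number 0.8 percentage points higher from compound 1 to compound 3 (within the scatter), is a different change, hydrogen in place of ethyl on an oxygen next to a carbonyl group, and it stays within the scatter. Compound 4 shares its chloro with compound 2, which carries another group on that oxygen and has no bromo partner, so the 12% of compound 2 does not speak to this swap.

The estimate therefore rests on the value of compound 3 alone. The expected step is a number 1.2 percentage points lower from compound 3 to compound 4 (within the scatter), with nothing expected beyond the scatter in either direction. For compound 4 the estimated value is 98%, with an expected range from 90% to 102%.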

Compound 4, percent of the compound remaining: 101%
Estimate against measurement, compound 4: 3 percentage points below; the measured number falls inside the stated range.
By their numbers in this assay, from the lowest: compound 2; then compounds 1, 3 and 4 (each within the scatter of the next).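

In this assay, the swap of bromo for chloro on this aromatic carbon, para to a large group, is now measured directly, and the step is a number 1.8 percentage points higher from compound 3 to compound 4 (within the scatter), so with the carboxy group in place the two halogens cannot be told apart. Chloro itself is also cleared of the low reading of compound 2: with chloro held constant, putting a hydrogen in place of the ring-bearing ester group on the oxygen gives a number 89 percentage points higher from compound 2 to compound 4 (beyond the scatter), which ties that large gap to the group on the oxygen. The step that changes both the halogen and the ethyl ester at once, a number 2.6 percentage points higher from compound 1 to compound 4 (within the scatter), shows that the two changes together also leave the read-out within the scatter.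

No measurement offered here explains why the group on the oxygen matters while the halogen does not. As far as these compounds go, whether the halogen swap would matter in a compound reading as low as compound 2 stays open, as does the outcome with fluoro, methyl or a plain hydrogen on this aromatic carbon, or with a methyl or isopropyl ester on the oxygen.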